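The source may hold more compounds than are shown below. What is called first, only, known or untested is meant among the compounds shown, and "the series" means these compounds.

Compound 2 `CCCCCCCCc1ccc(OCC(=O)Cn2nnc(-c3ccc(C(=O)OC)cc3)n2)cc1` is one of three compounds that share a single core and differ only in the aryl group attached to it. In an assay on microsomes from brain for inhibition of Fatty-acid amide hydrolase 1 (Rattus norvegicus), read by fluorescence and HPLC, with a stated time of 60 min (on this read-out higher numbers stand for weaker inhibition and lower numbers for stronger inhibition), compound 2 gives 29 nM, the second highest of the three numbers. Its nearest neighbour is compound 1 `CCCCCCCCc1ccc(OCC(=O)Cn2nnc(-c3cccc(Cl)c3)n2)cc1`, which gives 24 nM; the step of a 1.2-fold higher number from compound 1 to compound 2 (0.08 log units; within the scatter) is within the scatter, so the two cannot be ranked. The furthest is compound 3 `CCCCCCCCc1ccc(OCC(=O)Cn2nnc(-c3cccc(S(=O)(=O)N(C)C)c3)n2)cc1`, which gives 420 nM; the step of a 14-fold higher number from compound 2 to compound 3 (1.16 log units; beyond the scatter) is large and beyond the scatter, as is the step of an 18-fold higher number from compound 1 to compound 3 (1.24 log units; beyond the scatter).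

Compound 4 `CCCCCCCCc1ccc(OCC(=O)Cn2nnc(-c3cccnc3)n2)cc1` has not yet been measured in this assay. It differs from compound 2 in one place: pyridin-3-yl in place of 4-(methoxycarbonyl)phenyl on an aromatic carbon.

Going by the values given here, two measured steps bear on this change, both at the same position of the core. One, from compound 1 to compound 2, shows that exchanging the aryl group can leave the number essentially unchanged; the other, from compound 2 to compound 3, shows that such an exchange can also weaken inhibition sharply. With only these two precedents, and pyridin-3-yl being smaller than any aryl group measured so far, no step beyond the scatter is firmly expected, though a drift toward a higher number is considered the more likely outcome. For compound 4 the expected number in this assay is therefore 45 nM, within a range from 12 nM to 170 nM, which corresponds to an estimated step of a 1.6-fold higher number from compound 2 to compound 4 (0.19 log units; within the scatter).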

Compound 4, half-maximal inhibitory concentration: 23 nM
For compound 4 the middle estimate is 2.0-fold (0.29 log units) above the measured one, and the stated range covers the measured number.
By their numbers in this assay, from the lowest: compounds 4, 1 and 2 (each within the scatter of the next); then compound 3.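

In this assay, going by these compounds alone, the earlier compounds at this position all carried a substituted phenyl, and the new result shows that neither the chloro nor the methoxycarbonyl substituent is needed to keep the number in this range: pyridin-3-yl, with one six-membered aromatic ring with 1 hetero atom and no substituent, gives a 1.3-fold lower number from compound 2 to compound 4 (0.10 log units; within the scatter) and a 1.0-fold lower number from compound 1 to compound 4 (0.02 log units; within the scatter). Compound 3 now stands apart from three otherwise matched compounds, with an 18-fold lower number from compound 3 to compound 4 (1.26 log units; beyond the scatter), so among the compounds shown the large step goes with the 3-(dimethylsulfamoyl)phenyl group and not with exchanging the aryl group as such. No supporting measurement is available to explain why these groups give the numbers they do.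

The compounds shown leave open whether the ring nitrogen is tolerated elsewhere, as in pyridin-2-yl or pyridin-4-yl, and whether plain phenyl would fall in the same range. They also leave open what a carboxylic acid or an amine on the aryl ring would do, and whether a saturated ring such as piperidinyl could take the place of the aromatic one.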